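The compounds below may be only part of what the source reports. "The series", "measured", "known", "first", "only" and "open" are said of these compounds alone.

Measured in a functional assay on KG-1 cells (Homo sapiens) for antiproliferative activity, read by CCK-8 assay, with a stated time of 72 h (a higher number here means a weaker inhibitor, a lower number a stronger inhibitor), are three compounds:
compound 1 `Cc1ccc(C(=O)Nc2cccc(C(F)(F)F)c2)cc1-c1ccc2c(-c3ccc(C(=O)N4CCN(C)CC4)cc3)n[nH]c2c1` gives 300 nM
compound 2 `Cc1ccc(C(=O)Nc2cccc(C(F)(F)F)c2)cc1-c1ccc2c(-c3ccc(CN4CCN(C)CC4)cc3)n[nH]c2c1` gives 120 nM
compound 3 `CCCn1cc(-c2n[nH]c3cc(-c4cc(C(=O)Nc5cccc(C(F)(F)F)c5)ccc4C)ccc23)cn1` gives 358 nM

Compound 3 (358 nM) lies within the usual scatter of compound 1 (300 nM), while compound 2 (120 nM) shows the lowest number of the three. Compound 4 `Cc1ccc(C(=O)Nc2cccc(C(F)(F)F)c2)cc1-c1ccc2c(-c3cnn(CC(C)O)c3)n[nH]c2c1` departs from compound 3 by a single change (hydroxy in place of hydrogen on a saturated chain carbon bound to two saturated chain carbons), which turns 1-propyl-1H-pyrazol-4-yl into 1-(2-hydroxypropyl)-1H-pyrazol-4-yl.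

Within the data shown here, no measured step adds a hydroxy. Among the measured compounds shown here, the only step available (a 2.5-fold lower number from compound 1 to compound 2 (0.40 log units; beyond the scatter)) exchanges (4-methylpiperazin-1-yl)carbonyl for (4-methylpiperazin-1-yl)methyl on an aromatic carbon. It is a different change and bears only loosely, as a modest yardstick for a change in a side group. On that basis, no step beyond the scatter is firmly expected in this assay, and no direction can be favoured. The expected step is small (a 1.1-fold lower number from compound 3 to compound 4 (0.04 log units; within the scatter)). Compound 4 is estimated at 330 nM (range 130 nM to 850 nM).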

Compound 4, half-maximal inhibitory concentration: 339 nM
Compound 4: middle estimate off by 1.0-fold (0.01 log units), on the low side; the measured number falls inside the stated range.
By their numbers in this assay, from the lowest: compound 2; then compounds 1, 4 and 3 (each within the scatter of the next).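

In this assay, hydroxy in place of hydrogen on a saturated chain carbon bound to two saturated chain carbons gives a 1.1-fold lower number from compound 3 to compound 4 (0.02 log units; within the scatter) and so stays within the scatter. Among these compounds, this is the first step read on this chain: here the propyl chain takes a hydroxy, with its one hydrogen-bond donor and one hydrogen-bond acceptor, without a change in the number that can be told from scatter. Nothing available explains this outcome or bears on the hydroxy itself.

On these data alone, whether an amine or a carboxylic acid at this carbon, or a longer chain on the pyrazole nitrogen, would give a step beyond the scatter remains open. This single step also cannot show whether the same change would read alike on another chain or in another assay.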